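The source may report more compounds than this note shows. Statements on the series, on what has been measured and on what is new or still open speak of the compounds shown alone.

Compound 1 `O=C(Nc1ccc2c(c1)B(O)OC2)c1ccccc1C(F)(F)F` and compound 2 `O=C(Nc1ccc2c(c1)B(O)OC2)c1cccc(C(F)(F)F)c1` are built from the same atoms joined differently; how the two cores differ is not broken down here. In a functional assay on PBMC cells (Homo sapiens) for inhibition, read by HTRF, with stated times of 15 min and 24 h (a higher number here means a weaker inhibitor, a lower number a stronger inhibitor), compound 1 gives 4400 nM. In this assay compound 2 gives only a limit of the assay, > 10000 nM, at which (the limit of > 10000 nM in this assay, at which 1 of the 3 values shown sits). Compound 3 `O=C(Nc1ccc2c(c1)B(O)OC2)c1cc(F)ccc1C(F)(F)F`, in this assay, gives 8200 nM. The change fluoro in place of hydrogen on an aromatic carbon gave a 1.9-fold higher number from compound 1 to compound 3 (0.27 log units; within the scatter).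

Compound 4 `O=C(Nc1ccc2c(c1)B(O)OC2)c1cccc(C(F)(F)F)c1F`, not yet measured, arises from compound 2 by the same kind of change, (fluoro in place of hydrogen on an aromatic carbon), but at a different place: ortho to a large group and ortho to a trifluoromethyl group, rather than meta to a large group and para to a trifluoromethyl group. The earlier step lay within the scatter, so a step that the limit leaves unreadable from compound 2 to compound 4 is expected here, resting on compound 2 standing at a limit, > 10000 nM. Compound 4 is therefore estimated at 15000 nM, likely between 5000 nM and 50000 nM.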

Compound 4, half-maximal inhibitory concentration: > 100000 nM
Compound 4 ended at the assay's limit (the forecaster's own chance of this, stated with the estimate: 70%); middle value at least 6.6-fold (0.82 log units) from the limit.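

The step from compound 2 to compound 4 cannot be read: both compounds carry only a limit in this assay, not a number. The compounds shown leave open how much fluoro at this place changes inhibition.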